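Three measured amides and a pyrrolidine to come

This account rests on a few compounds, and the source may have more. Where it says the series, first, only, none or still open, it means among the compounds named here.

Compound 1 `CCCNC(=O)Nc1cccc2c1CN(C)CC2c1ccccc1` gives > 80 mg/kg (a limit)
Compound 2 `CCCCOC(=O)Nc1cccc2c1CN(C)CC2c1ccccc1` gives 2.6 mg/kg (a number)
Compound 3 `CCNCCC(=O)Nc1cccc2c1CN(C)CC2c1ccccc1` gives > 160 mg/kg (a limit)

In a functional assay on the whole organism for inhibition, with Mus musculus as the target (on this read-out lower numbers stand for an effect already at smaller amounts and higher numbers for an effect only at larger amounts of compound), compound 3 gives > 160 mg/kg as a limit only. Compound 4 `CN1Cc2c(NC(=O)CN3CCCC3)cccc2C(c2ccccc2)C1` carries pyrrolidin-1-yl in place of (ethylamino)methyl on a saturated chain carbon bound to a carbonyl carbon. Among the compounds with values here, no measured step makes this change, and each one swaps the whole group on the carbonyl carbon. Both an at least 30-fold lower number from compound 1 to compound 2 (1.48 log units; beyond the scatter) and an at least 61-fold higher number from compound 2 to compound 3 (1.78 log units; beyond the scatter) are large steps involving butoxy, whereas a step that the two limits leave unreadable from compound 1 to compound 3 stays unsized between two limits. Neither group in this change is butoxy, so no step beyond the scatter is expected in this assay here. The expected step is an at least 1.2-fold lower number from compound 3 to compound 4 (0.09 log units; that floor lies within the scatter) by this estimate. Compound 4 is estimated at 130 mg/kg with an expected range of 40 mg/kg to 400 mg/kg for now.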

Compound 4, dose for half-maximal effect: about 25 mg/kg
For compound 4 the middle estimate is 5.2-fold (0.72 log units) above the measured one; the whole stated range lies above it.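

In this assay, within the data shown here, compound 4 is the first compound without butoxy on the carbonyl carbon to give a readable number, and the change at the saturated chain carbon shows an at least 6.4-fold lower number from compound 3 to compound 4 (0.80 log units; beyond the scatter). Among these compounds, its other steps are an at least 3.2-fold lower number from compound 1 to compound 4 (0.50 log units; beyond the scatter) and a 9.6-fold higher number from compound 2 to compound 4 (0.98 log units; beyond the scatter), so butoxy is not the only group here whose steps lie beyond the scatter. The step from compound 3 is only a floor because that compound stands at a limit: the limit of > 160 mg/kg in this assay, at which 1 of the 4 values shown sits.

On these data alone, whether the pyrrolidin-1-yl ring itself matters stays open, as a piperidin-1-yl ring or a dimethylamino group on the same saturated chain carbon could separate the ring from the lost hydrogen-bond donor.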